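The source may hold more compounds than are shown below. What is called first, only, known or untested is meant among the compounds shown, and "the series" means these compounds.

Working notes on the series. Within the data shown here, compound 3, `C=CC(=O)Nc1cccc(Nc2nc(N/N=C(\C)c3cccc(OC)c3)ncc2Cl)c1`, gives 8990 nM in an ADME assay on HT-29 cells (Homo sapiens) for inhibition, read by MTT assay, with a stated time of 72 h (on this read-out lower numbers stand for stronger inhibition and higher numbers for weaker inhibition), the largest of the three numbers measured so far; compound 1, `C=CC(=O)Nc1cccc(Nc2nc(N/N=C/c3ccc(F)cc3)ncc2Cl)c1`, sits within the scatter of it at 6340 nM, while compound 2, `C=CC(=O)Nc1cccc(Nc2nc(N/N=C(\C)c3ccc(C)cc3)ncc2Cl)c1`, lies further off at 3210 nM. Among the measured compounds shown here, the one step that exceeds the scatter is a 2.8-fold higher number from compound 2 to compound 3 (0.45 log units; beyond the scatter), a swap of the aryl group on the carbon with a double bond to nitrogen. The other step, a 2.0-fold lower number from compound 1 to compound 2 (0.30 log units; within the scatter), also exchanges the aryl group at that position and stays within the scatter.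

Compound 4, `C=CC(=O)Nc1cccc(Nc2nc(N/N=C(\C)c3ccncc3)ncc2Cl)c1`, differs from compound 3 by pyridin-4-yl in place of 3-methoxyphenyl on a carbon with a double bond to nitrogen. Both measured steps bear on it, since each exchanges the aryl group at the same place, and they ran from within the scatter to a modest change. For the measured compounds named here, no measured compound carries an aromatic ring with a hetero atom at this position, so the direction of any step is open. On that basis the step of a 1.3-fold lower number from compound 3 to compound 4 (0.11 log units; within the scatter) is expected to stay within the scatter, with a wide range allowed. Compound 4 is therefore estimated at 7000 nM in this assay, with a range from 2500 nM to 20000 nM.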

Compound 4, half-maximal inhibitory concentration: 12800 nM
For compound 4 the middle estimate is 1.8-fold (0.26 log units) below the measured one, and the stated range covers the measured number.
By their numbers in this assay, from the lowest: compounds 2, 1, 3 and 4 (each within the scatter of the next, the first and the last beyond it).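

Among the compounds shown, pyridin-4-yl is the only aromatic ring with a hetero atom on the carbon with a double bond to nitrogen, and in this assay it cannot be told apart from 3-methoxyphenyl (a 1.4-fold higher number from compound 3 to compound 4 (0.15 log units; within the scatter)). Against 4-methylphenyl the same ring gives the largest step in the series so far (a 4.0-fold higher number from compound 2 to compound 4 (0.60 log units; beyond the scatter)), so 4-methylphenyl now stands apart from both 3-methoxyphenyl and pyridin-4-yl, with each of those two steps beyond the scatter. The step to compound 4 from the fluorophenyl compound is also beyond the scatter (a 2.0-fold higher number from compound 1 to compound 4 (0.31 log units; beyond the scatter)), but it exchanges the whole group on a nitrogen on an aromatic ring, so it cannot be assigned to the aromatic ring alone.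

Still open is whether a dimethylamino group or a carboxylic acid on the aromatic ring, or a longer chain in place of the saturated chain carbon, would move the number in either direction, and the compounds shown do not separate the hetero atom from the loss of the methoxy or methyl group. No measurement at hand accounts for any of these steps.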